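This account rests on a few compounds, and the source may have more. Where it says the series, first, only, none or still open, it means among the compounds named here.

Measured so far:
- Compound 1 `C[C@H]1CC[C@H]2C(=CC(=O)CC2(C)C)[C@@]1(C)CCC(CCCc1ccoc1)COS(=O)(=O)O`: > 100 ug/mL
- Compound 2 `C[C@H]1CC[C@H]2C(=CCCC2(C)C)[C@@]1(C)CCC(CCCC1=CC(=O)OC1)COS(=O)(=O)O`: > 100 ug/mL

Both compounds were tested in a functional assay on K562 cells (Homo sapiens) for cytotoxicity, read by MTT assay; on this read-out higher numbers stand for lower toxicity in this test and lower numbers for higher toxicity in this test. Compound 1 gives > 100 ug/mL, which is a limit of the assay and not a number. Compound 2 gives > 100 ug/mL, which is likewise a limit and not a number. Compound 2 therefore shares its place with the only other result available: the limit of > 100 ug/mL in this assay, at which 2 of the 2 values shown sit.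

Compound 3 `COC1C=C(CCCC(CC[C@]2(C)C3=CCCC(C)(C)[C@H]3CC[C@@H]2C)COS(=O)(=O)O)C(=O)O1` has not yet been measured. It differs from compound 2 as follows: a group of 8 heavy atoms (5 carbon, 3 oxygen; one five-membered non-aromatic ring with 1 hetero atom) in place of a group of 6 heavy atoms (4 carbon, 2 oxygen; one five-membered non-aromatic ring with 1 hetero atom), on a saturated chain carbon, five bonds along the chain from an oxygen on an unsaturated carbon. Both the group that leaves and the group that enters hold one five-membered non-aromatic ring with 1 hetero atom. The change sits on a saturated chain carbon, five bonds along the chain from an oxygen on an unsaturated carbon.

Among the compounds with values here, no measured step shows what such a change does in this assay, so no clear move in either direction is expected. The expectation rests on compound 2, whose limit is > 100 ug/mL. The estimated change is a number no higher from compound 2 to compound 3 (the limit leaves the size open), and it is expected to stay within the usual scatter. For compound 3 the expected value is 100 ug/mL, with an estimated range of 50 ug/mL to 200 ug/mL.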

Compound 3, concentration lethal to 50% of the cells: > 100 ug/mL
Compound 3: only a limit was reported (the forecaster's own chance of this, stated with the estimate: 60%); the middle value lies on the limit itself.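

Compound 3 gives > 100 ug/mL, which is a limit and not a number. Compound 2 also sits at a limit, so the step from compound 2 to compound 3 cannot be read, and all the results stand together: the limit of > 100 ug/mL in this assay, at which 3 of the 3 values shown sit.

The compounds shown leave open how far each lies beyond that limit and whether the exchanged group changes toxicity at all.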